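Lengthening the Chain of Compound 3

The source may hold more compounds than are shown below. What is called first, only, known or untested is meant among the compounds shown, and "the series" means these compounds.

Measured in a functional assay on HL-60 cells (Homo sapiens) for cytotoxicity, read by WST assay, with a stated time of 48 h; a lower number here means a stronger inhibitor, a higher number a weaker inhibitor:
compound 1 `COC[C@H](C)[C@H](C)C(c1ccc(O)c(OC)c1)c1ccc(O)c(OC)c1`: 82000 nM
compound 2 `COc1cc(C(c2ccc(O)c(OC)c2)[C@H](C)[C@H](C)CO)ccc1O`: > 100000 nM, a limit of the assay
compound 3 `CC[C@H](C(C)C)C(c1ccc(O)c(OC)c1)c1ccc(O)c(OC)c1`: 16000 nM

Compound 3 holds the lowest number of the three in this assay, with a 5.1-fold lower number from compound 1 to compound 3 (0.71 log units; beyond the scatter) and an at least 6.2-fold lower number from compound 2 to compound 3 (0.79 log units; beyond the scatter). The second of these steps rests on (the limit of > 100000 nM in this assay, at which 1 of the 3 values shown sits). The next compound, compound 4 `CCCCC[C@H](C(C)C)C(c1ccc(O)c(OC)c1)c1ccc(O)c(OC)c1`, differs from compound 3 by propyl in place of hydrogen on a saturated chain carbon, four bonds along the chain from two aromatic carbons. The same change reads 1-isopropylhexyl for 1-isopropylpropyl.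

For the measured compounds named here, no measured step lengthens a chain, so the evidence is indirect. The closest guides are the two steps to compound 3, where 1-isopropylpropyl replaced a chain ending in methoxymethyl or hydroxymethyl. Going by compound 3 and a 5.1-fold lower number from compound 1 to compound 3 (0.71 log units; beyond the scatter), a modest move to a lower number is expected in this assay, though a step within the scatter would not surprise. The estimate amounts to an expected 2.7-fold lower number from compound 3 to compound 4 (0.43 log units; beyond the scatter). For compound 4 the expected value is 6000 nM, with an estimated range of 1800 nM to 20000 nM.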

Compound 4, half-maximal inhibitory concentration: 9600 nM
Compound 4: the middle estimate sits 1.6-fold (0.20 log units) below what was measured; measured number inside the range.
By their numbers in this assay, from the lowest: compounds 4 and 3 (each within the scatter of the next); then compound 1. At a limit, above all of these: compound 2.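

In this assay, for the compounds shown here, the first direct look at chain length at this place gives a 1.7-fold lower number from compound 3 to compound 4 (0.22 log units; within the scatter), so compound 3 and compound 4 cannot be told apart. Propyl in place of hydrogen, four bonds along the chain from two aromatic carbons, therefore leaves the number within the scatter, while the gaps to the chains ending in methoxymethyl and hydroxymethyl remain: an 8.5-fold lower number from compound 1 to compound 4 (0.93 log units; beyond the scatter), and an at least 10-fold lower number from compound 2 to compound 4 (1.01 log units; beyond the scatter). The second of these steps rests on a limit of compound 2: the limit of > 100000 nM in this assay, at which 1 of the 4 values shown sits.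

The compounds shown leave open whether a longer chain, an amine or a carboxylic acid in place of propyl at this place would keep the number in this assay where compound 3 and compound 4 stand. They also leave open whether propyl would give a similar step on the chains of compound 1 or compound 2.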